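Cytotoxicity notes: one nitro removed from compound 2

A few compounds are considered here, and "the series" means these few. Any claim that something is new, unique, unknown or untested is made for them only; others in the source may bear on it.

Measured so far in an ADME assay on MDBK cells (Bos taurus) for cytotoxicity, read by MTT assay, with a stated time of 96 h; a higher number here means that more compound is tolerated, a lower number that less compound is tolerated:
- compound 1, `Fc1ccc(-c2nc3cc(C(F)(F)F)ccc3[nH]2)cc1`, gives 19000 nM
- compound 2, `O=[N+]([O-])c1ccc(-c2nc3ccccc3[nH]2)c([N+](=O)[O-])c1`, gives 20000 nM

Compound 2 holds the higher of the two numbers in this assay, but compound 1 sits nearest with a number that lies within the scatter, so no order between the two is claimed; both are tolerated to about the same concentration despite carrying quite different substituents on the shared core.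

Compound 3, `O=[N+]([O-])c1ccccc1-c1nc2ccccc2[nH]1`, is not yet measured. Compared with compound 2 it shows this change: hydrogen in place of nitro on an aromatic carbon. Going by the values given here, no step between two measured compounds that differ in only one place is available, and compound 1 and compound 2 differ in more than one place, so their values show only that two distinct substitution patterns land close together. On that footing, the loss of one nitro is expected to give no step beyond the scatter in this assay, with the expected step being no change at the digits printed from compound 2 to compound 3 (within the scatter). Compound 3 is therefore estimated at 20000 nM, in the range 8000 nM to 50000 nM.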

Compound 3, half-maximal cytotoxic concentration: > 100000 nM
Compound 3 gave a limit, no number (the forecaster's own chance of this, stated with the estimate: 15%); middle value at least 5.0-fold (0.69 log units) from the limit.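

In this assay the series now has its first comparison across a single place: hydrogen in place of nitro on an aromatic carbon gives an at least 5.0-fold higher number from compound 2 to compound 3 (0.69 log units; beyond the scatter). This shows that the position, meta to a nitro group and para to a group of 9 heavy atoms, is not neutral in this read-out, something the earlier pair could not show, as compound 1 and compound 2 differ in more than one place. The size of the step stays open upward, as compound 3 gives a limit of the assay and not a number: the limit of > 100000 nM in this assay, at which 1 of the 3 values shown sits.

Only nitro and hydrogen are shown at this aromatic carbon, so it remains open whether the step belongs to nitro in particular or would also appear with another group there, such as an amine, a methoxy group or a carboxylic acid. From the compounds shown here alone, the role of the remaining nitro in compound 3 is equally open, as is whether the same change would give a similar step on a compound carrying other substituents on the shared core.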